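Swapping a Methoxyphenyl for an Isopropylphenyl

The compounds below may be only part of what the source reports. "The series", "measured", "known", "first", "only" and "open" are said of these compounds alone.

Three compounds share one core and differ only in the aryl group on a double-bonded chain carbon bound to a double-bonded chain carbon. In a functional assay on MCF7 cells (Homo sapiens) for antiproliferative activity (on this read-out lower numbers stand for stronger inhibition and higher numbers for weaker inhibition), compound 1 `COc1ccc(/C=C/C(=O)c2ccc(OCCn3cc(CN4C(=O)/C=C/C(C)(C)C/C=C(\C)CC/C=C/4C)nn3)cc2O)cc1` gives 2.85 ug/mL. Compound 2 `COc1cccc(/C=C/C(=O)c2ccc(OCCn3cc(CN4C(=O)/C=C/C(C)(C)C/C=C(\C)CC/C=C/4C)nn3)cc2O)c1` gives 1.12 ug/mL, and compound 3 `COc1ccccc1/C=C/C(=O)c1ccc(OCCn2cc(CN3C(=O)/C=C/C(C)(C)C/C=C(\C)CC/C=C/3C)nn2)cc1O` gives 1.17 ug/mL. Compound 2 shows the lowest of the three numbers, but compound 3 sits within the scatter of it, so the two cannot be ranked; only compound 1 stands clearly apart, through a 2.5-fold lower number from compound 1 to compound 2 (0.41 log units; beyond the scatter) and a 2.4-fold lower number from compound 1 to compound 3 (0.39 log units; beyond the scatter).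

Compound 4 `C/C1=C\CC(C)(C)/C=C/C(=O)N(Cc2cn(CCOc3ccc(C(=O)/C=C/c4ccc(C(C)C)cc4)c(O)c3)nn2)/C(C)=C/CC1` carries the change (4-isopropylphenyl in place of 3-methoxyphenyl on a double-bonded chain carbon bound to a double-bonded chain carbon). For the measured compounds named here, no measured step exchanges a methoxy group for an isopropyl group, so the size of that exchange is unknown. Going by the values given here, the measured steps show only that moving the methoxy group around the ring shifts the number modestly, as in a 2.5-fold lower number from compound 1 to compound 2 (0.41 log units; beyond the scatter). A shift of about that size, most likely toward a higher number, is therefore the expectation. Compound 4 is expected to give about 2 ug/mL in this assay, within a range from 0.9 ug/mL to 4.5 ug/mL. That amounts to an expected step of a 1.8-fold higher number from compound 2 to compound 4 (0.25 log units; within the scatter).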

Compound 4, half-maximal inhibitory concentration: 0.93 ug/mL
Compound 4: the middle estimate sits 2.2-fold (0.33 log units) above what was measured; the range from low to high includes it.
By their numbers in this assay, from the lowest: compounds 4, 2 and 3 (each within the scatter of the next); then compound 1.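

The 4-isopropylphenyl group is accepted at this position: compound 4 cannot be separated from the two best methoxy compounds (a 1.2-fold lower number from compound 2 to compound 4 (0.08 log units; within the scatter); a 1.3-fold lower number from compound 3 to compound 4 (0.10 log units; within the scatter)). Compound 1 gives the cleanest comparison, since its 4-methoxyphenyl group has the same numbering as the new group, and here isopropyl in place of methoxy on an aromatic carbon gives a clear step (a 3.1-fold lower number from compound 1 to compound 4 (0.49 log units; beyond the scatter)). In these compounds, then, the ring substituent need not contain oxygen or a hydrogen-bond acceptor to reach this level, although no measurement here explains the result.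

Still open, on these data alone, is how the number would respond to a phenyl ring carrying a carboxylic acid or a dimethylamino group in this place. It is also unclear whether 3-isopropylphenyl or 2-isopropylphenyl would read like compound 4.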